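This account rests on a few compounds, and the source may have more. Where it says the series, first, only, none or still open, it means among the compounds named here.

Measured in a functional assay on LNCaP cells (Homo sapiens) for antiproliferative activity, read by propidium iodide staining, with a stated time of 96 h; on this read-out lower numbers stand for stronger inhibition and higher numbers for weaker inhibition:
- compound 1 `CC(O)(CSc1ccc(C(F)(F)F)cn1)C(=O)Nc1ccc(S(F)(F)(F)(F)F)cc1`: 12300 nM
- compound 2 `CC(O)(COc1cccc(S(F)(F)(F)(F)F)c1)C(=O)Nc1cc(C(F)(F)F)cc(C(F)(F)F)c1`: 3000 nM
- compound 3 `CNC(=O)c1ccc(N2C(=S)N(c3ccc(S(F)(F)(F)(F)F)cc3)C(=O)C2(C)C)cc1F`: 23000 nM

Compound 2 stands lowest of the three at 3000 nM, and its gaps to compound 1 and to compound 3 both lie beyond the scatter. Compound 4 `CC(O)(COc1cccc(C(F)(F)C(F)(F)F)c1)C(=O)Nc1cc(C(F)(F)F)cc(C(F)(F)F)c1` departs from compound 2 in one place: a group of 7 heavy atoms (2 carbon, 5 fluorine; no ring) in place of a group of 6 heavy atoms (5 fluorine, 1 sulfur; no ring), on an aromatic carbon. The entering group is 1,1,2,2,2-pentafluoroethyl, on an aromatic carbon, meta to a large group. Among the compounds with values here, no measured pair of compounds isolates this change, so the expectation rests on the close match in the counts alone. In this assay, the expected step of a 1.1-fold lower number from compound 2 to compound 4 (0.03 log units; within the scatter) stays within the scatter, with no firm direction. Compound 4 is estimated at 2800 nM, with an expected range of 1100 nM to 7500 nM.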

Compound 4, half-maximal inhibitory concentration: 4400 nM
Compound 4: the middle estimate sits 1.6-fold (0.20 log units) below what was measured; measured number inside the range.
By their numbers in this assay, from the lowest: compounds 2 and 4 (each within the scatter of the next); then compounds 1 and 3 (each within the scatter of the next).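

In this assay the exchange of the group of 5 fluorine and 1 sulfur atoms for 1,1,2,2,2-pentafluoroethyl on this aromatic carbon gives a 1.5-fold higher number from compound 2 to compound 4 (0.17 log units; within the scatter) and so gives the series its first single-place comparison. At this position the two groups cannot be separated in this read-out, at least on this core. No measured evidence bears on this result. Still open, on these data alone, is how an amine or a carboxylic acid would read at this position. Also open, as far as these compounds go, is whether the same exchange would behave alike on the core of compound 1 or compound 3.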